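The source may hold more compounds than are shown below. What is called first, only, known or untested is meant among the compounds shown, and "the series" means these compounds.

Compound 1, `COc1ccccc1-c1ccc([C@H]2S[C@@H](C)C(=O)Nc3c2c(C)nn3-c2ccccc2C)cc1`: 50% in an assay on isolated protein for agonist activity at Bile acid receptor (Homo sapiens), read by AlphaScreen, with a stated time of 30 min; a lower number here means a smaller maximal response, a higher number a larger maximal response
Compound 2, `COc1ccc(Oc2ccc([C@H]3S[C@@H](C)C(=O)Nc4c3c(C)nn4-c3ccccc3C)cc2)cc1`: 70%
Compound 3, `CCOc1cccc(-c2ccc([C@H]3S[C@@H](C)C(=O)Nc4c3c(C)nn4-c3ccccc3C)cc2)c1`: 13%

Compound 3 has the lowest of the three numbers in this assay; the nearest is compound 1, reached by a number 37 percentage points lower from compound 1 to compound 3 (beyond the scatter), and the furthest is compound 2, reached by a number 57 percentage points lower from compound 2 to compound 3 (beyond the scatter). Compound 4, `Cc1ccccc1-n1nc(C)c2c1NC(=O)[C@H](C)S[C@@H]2c1ccc(-c2ccco2)cc1`, arises from compound 3 by furan-2-yl in place of 3-ethoxyphenyl on an aromatic carbon. Among the compounds with values here, both measured steps that arrive at the 3-ethoxyphenyl group of compound 3 were large falls, so taking that group away is expected to move the number upward again, although no measured step involves furan-2-yl itself, which leaves the size uncertain. The expected step is a number 27 percentage points higher from compound 3 to compound 4 (beyond the scatter). Compound 4 is therefore estimated to give 40% in this assay, within a range from 15% to 65%.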

Compound 4, largest response reached (reported as efficacy), in percent of the reference or control that the assay uses: 32%
Compound 4: middle estimate off by 8 percentage points, on the high side; the range from low to high includes it.
By their numbers in this assay, from the lowest: compound 3; then compound 4; then compound 1; then compound 2.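

Furan-2-yl, with its five-membered aromatic ring, keeps a response on this aromatic carbon para to a large group, and exchanging the larger 3-ethoxyphenyl for it gives a rise (a number 19 percentage points higher from compound 3 to compound 4 (beyond the scatter)). The smaller ring still falls short of both other groups (a number 18 percentage points lower from compound 1 to compound 4 (beyond the scatter); a number 38 percentage points lower from compound 2 to compound 4 (beyond the scatter)), so fewer heavy atoms alone do not give the largest response here. No available evidence explains these differences. As far as these compounds go, whether furan-3-yl, a carboxylic acid or an amine at this position would match 4-methoxyphenoxy remains open.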